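Shared core, varied aryl group: a step to compound 4

The source may hold more compounds than are shown below. What is called first, only, known or untested is meant among the compounds shown, and "the series" means these compounds.

Of the compounds shown here, three built on one shared core have been tested in a functional assay on A549 cells (Homo sapiens) for inhibition, read by CCK-8 assay, with a stated time of 48 h; a higher number here means a weaker inhibitor, a lower number a stronger inhibitor. Compound 1, `COc1cc(-c2cc3nccc(-c4cc(OC)c(OC)c(OC)c4)n3n2)cc(OC)c1OC`, gives only a limit of the assay, > 10000 nM, as the limit of > 10000 nM in this assay, at which 1 of the 3 values shown sits, records. Compound 2, `COc1cc(-c2ccnc3cc(-c4cn(CO)c5ccccc45)nn23)cc(OC)c1OC`, gives 167 nM in this assay. Within the data shown here, compound 3, `COc1cc(-c2ccnc3cc(-c4ccc(C)c(C)c4)nn23)cc(OC)c1OC`, gives 272 nM in this assay; of the two reported numbers, compound 3 is the one not separated from compound 2 by more than the usual scatter of repeated measurements. Among the measured compounds shown here, no pair among the measured compounds differs in a single place, so no measured step is available.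

Compound 4, `COc1ccc(-c2cc3nccc(-c4cc(OC)c(OC)c(OC)c4)n3n2)cc1F`, has not yet been measured. It differs from compound 3 by 3-fluoro-4-methoxyphenyl in place of 3,4-dimethylphenyl on an aromatic carbon. For the measured compounds named here, with no measured step to rest on, only a modest move is expected, most likely toward a slightly weaker inhibitor or none beyond the scatter. The expected step of a 1.5-fold higher number from compound 3 to compound 4 (0.17 log units; within the scatter) is estimated to stay within the scatter. Compound 4 is therefore expected to give about 400 nM in this assay, with a likely range from 120 nM to 1500 nM.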

Compound 4, half-maximal inhibitory concentration: 545 nM
For compound 4 the middle estimate is 1.4-fold (0.13 log units) below the measured one; the range from low to high includes it.
By their numbers in this assay, from the lowest: compounds 2, 3 and 4 (each within the scatter of the next, the first and the last beyond it). At a limit, above all of these: compound 1.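

In this assay, among these compounds, the exchange of 3,4-dimethylphenyl for 3-fluoro-4-methoxyphenyl gives the first measured step at this aromatic carbon of the five-membered ring, a 2.0-fold higher number from compound 3 to compound 4 (0.30 log units; within the scatter). The earlier compounds shown here offered no comparison in a single place, whereas this pair shows that a ring bearing fluorine and methoxy, with one hydrogen-bond acceptor where 3,4-dimethylphenyl has none, reads within the scatter of the dimethyl ring. Nothing measured here bears on why these two compounds read as they do.

Fluorine and methoxy enter together in this step, so what each contributes alone remains open. On these data alone, it is also open how the assay would read with an amine or a carboxylic acid on this aryl ring in their place.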